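The source may report more compounds than this note shows. Statements on the series, on what has been measured and on what is new or still open speak of the compounds shown alone.

Measured compounds in a functional assay on the whole organism for antagonist activity, with Mus musculus as the target; on this read-out higher numbers stand for an effect only at larger amounts of compound and lower numbers for an effect already at smaller amounts:
Compound 1, `CCCN1CCC(C(=O)Nc2cc(Cl)c(N)cc2OC)CC1`, gives > 10 mg/kg, which is a limit of the assay and not a number.
Compound 2, `COc1cc(N)c(Cl)cc1NC(=O)C1CCN(CC2CCC2)CC1`, gives > 10 mg/kg, likewise a limit.
Compound 3, `COc1cc(N)c(Cl)cc1NC(=O)C1CCN(CC2CCCCCC2)CC1`, gives > 10 mg/kg, again a limit.

Going by the values given here, compound 3 thus stands at the limit of > 10 mg/kg in this assay, at which 3 of the 3 values shown sit, and no compound in this set has a readable number. Compound 4, `CCCCCN1CCC(C(=O)Nc2cc(Cl)c(N)cc2OC)CC1`, differs from compound 3 by butyl in place of cycloheptyl on a saturated chain carbon bound to an amine nitrogen in a ring. Among the compounds with values here, the steps that bear on this change are a step that the two limits leave unreadable from compound 1 to compound 3 and a step that the two limits leave unreadable from compound 2 to compound 3, both left unreadable by the two limits, so nothing shows how large a change at this position can be. The step from compound 3 to compound 4 is therefore expected to be a step that the limit leaves unreadable from compound 3 to compound 4, with no direction readable. Compound 4 is estimated at 15 mg/kg in this assay, in a range from 4 mg/kg to 60 mg/kg.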

Compound 4, dose for half-maximal effect: > 10 mg/kg
Compound 4: only a limit was reported (the forecaster's own chance of this, stated with the estimate: 75%); the middle value does not contradict the limit.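

Compound 4 gives > 10 mg/kg in this assay, which is a limit and not a number. Going by these compounds alone, no step from compound 1, compound 2 or compound 3 to compound 4 can be read: the limit of > 10 mg/kg in this assay, at which 4 of the 4 values shown sit. The compounds shown leave open how far the group at this position can shift the dose for half-maximal effect.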